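Methyl to Trifluoromethyl: Estimating Compound 3

A few compounds are considered here, and "the series" means these few. Any claim that something is new, unique, unknown or untested is made for them only; others in the source may bear on it.

Of the compounds shown here, two have so far been measured in a functional assay on HeLa cells (Homo sapiens), with a stated time of 3 days; on this read-out higher numbers stand for weaker inhibition and lower numbers for stronger inhibition. Compound 1 `C=C1C=CCO[C@@H]1n1ccc(NC(=O)c2ccccc2)nc1=O` gives 296000 nM in this assay, a weak result. Compound 2 `Cc1cn([C@H]2OCC=CC2=O)c(=O)nc1O` gives 34000 nM in this assay, the lower of the two numbers, and its gap to compound 1 lies beyond the usual scatter of repeated measurements.

Compound 3 `O=C1C=CCO[C@@H]1n1cc(C(F)(F)F)c(O)nc1=O` has not been measured. It differs from compound 2 in a single place: trifluoromethyl in place of methyl on an aromatic carbon. Within the data shown here, no measured pair shows this exchange, so the expectation rests on the value of compound 2 and on the nature of the change alone.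

Compound 3 is expected to come out somewhat lower than compound 2, with an estimated step of a 2.3-fold lower number from compound 2 to compound 3 (0.36 log units; beyond the scatter). The size of that step is uncertain, and a result within the scatter of compound 2 cannot be ruled out. In this assay compound 3 is estimated at about 15000 nM, with a range from 3000 nM to 60000 nM.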

Compound 3, half-maximal inhibitory concentration: 34000 nM
The estimate for compound 3 lay 2.3-fold (0.36 log units) below the measured number, and the stated range covers the measured number.
By their numbers in this assay, from the lowest: compounds 2 and 3 (each within the scatter of the next); then compound 1.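

Exchanging methyl for trifluoromethyl on the aromatic carbon ortho to the hydroxy group gives no change at the digits printed from compound 2 to compound 3 (within the scatter) in this assay. Among these compounds, this position therefore takes a group of four heavy atoms in place of a group of one with no shift beyond normal assay noise, which the earlier compounds could not show, since neither had a partner differing from it in one place. Nothing available explains why the two groups read alike.

This is a single pair on a single core, so it sets no general rule for the position, and only these two groups can be compared here. On these data alone, whether an amine, a carboxylic acid or a longer chain such as propyl would also leave the number in place remains open.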